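The source may report more compounds than this note shows. Statements on the series, on what has been measured and on what is new or still open speak of the compounds shown alone.

Working notes on the series.

Three compounds have numbers in an ADME assay on microsomes from liver (Mus musculus) for metabolic stability, read by mass spectrometry, with a stated time of 10 min, tested at 0.5 uM; a higher number here means that more of the compound is left, a lower number that less of the compound is left. Compound 1 `CNc1cc(Nc2cccc(C(C)(C)C)c2)nn2c(C(N)=O)cnc12` gives 3% in this assay. Compound 2 `CNc1cc(Nc2cc(C)cc(C)c2)nn2c(C(N)=O)cnc12` gives 6% in this assay. Compound 3 `NC(=O)c1cnc2c(NC3CC3)cc(Nc3cccc(-c4ccc(C(F)(F)F)cc4F)c3)nn12` gives 65% in this assay, the highest of the three; the gap to compound 2 and the gap to compound 1 both lie beyond the scatter, so compound 3 stands alone at the top of what has been measured.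

Compound 4 `C[C@](O)(CO)CNc1cc(Nc2cccc(-c3ccc(C(F)(F)F)cc3F)c2)nn2c(C(N)=O)cnc12` has not yet been run in this assay. Its difference from compound 3 is 2-hydroxy-2-(hydroxymethyl)propyl in place of cyclopropyl on a nitrogen on an aromatic ring. The rest of the structure, including the amide and the biaryl part bearing the trifluoromethyl group, is unchanged.

Going by the values given here, no step between measured compounds touches this position, so there is nothing in the measured set to anchor the size of the change. The expected step of a number 5 percentage points lower from compound 3 to compound 4 (within the scatter) is small and within the scatter, in either direction. Compound 4 is expected to show about 60% in this assay, within a range from 35% to 85%.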

Compound 4, percent of the compound remaining: 34%
The estimate for compound 4 lay 26 percentage points above the measured number; measured number outside the range, below it.
By their numbers in this assay, from the lowest: compounds 1 and 2 (each within the scatter of the next); then compound 4; then compound 3.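

In this assay this position is not a silent one: with the rest of the structure unchanged, 2-hydroxy-2-(hydroxymethyl)propyl in place of cyclopropyl on a nitrogen on an aromatic ring results in a number 31 percentage points lower from compound 3 to compound 4 (beyond the scatter), a large step beyond the scatter. Going by these compounds alone, this is the first step that isolates this position, and the earlier compounds gave no size for a change here. No evidence at hand bears on the cause of the step.

One step cannot separate the loss of the cyclopropyl ring from the entry of the open chain with its two hydroxyl groups. Going by these compounds, a plain isobutyl chain or a 2-hydroxyethyl chain on the same nitrogen would help to tell these apart, and the role of the defined stereocentre also remains open.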